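The source may hold more compounds than are shown below. What is called first, only, known or untested is meant among the compounds shown, and "the series" means these compounds.

Compound 1 `O=C(Nc1ccc(Cl)c(-c2nnc3c(Cl)cccn23)c1)c1ccc(C(F)(F)F)cc1Cl` gives 81600 nM.
Compound 3 `O=C(Nc1ccc(Cl)c(-c2nnc3c(Cl)cccn23)c1)c1ccc(C(F)(F)F)cc1F` gives 62800 nM.
Compound 2 `Cc1nc(C(=O)Nc2ccc(Cl)c(-c3nnc4c(Cl)cccn34)c2)cs1` gives > 100000 nM.

These values come from a functional assay on MCF7 cells (Homo sapiens) for antiproliferative activity, read by MTT assay, with a stated time of 72 h; a lower number here means a stronger inhibitor, a higher number a weaker inhibitor. Compound 1 and compound 3 carry a six-membered carbon ring on the carbonyl and both sit at weak numbers; the step of a 1.3-fold lower number from compound 1 to compound 3 (0.11 log units; within the scatter) is small. For compound 2 the assay reports only a limit, (the limit of > 100000 nM in this assay, at which 1 of the 3 values shown sits), so it stands at the weak end without a number. Compound 4 `CS(=O)(=O)c1ccc(C(=O)Nc2ccc(Cl)c(-c3nnc4c(Cl)cccn34)c2)cc1` differs from compound 2 in one place: 4-(methylsulfonyl)phenyl in place of 2-methyl-1,3-thiazol-4-yl on a carbonyl carbon. Among the measured compounds shown here, no measured step touches the group on the carbonyl, so none bears directly on this change; the only guide is that compound 1 and compound 3, which carry a six-membered carbon ring there, give weak numbers. Compound 4 is therefore expected near them, with the step of an at least 1.4-fold lower number from compound 2 to compound 4 (0.15 log units; that floor lies within the scatter) from a limit not sizable. Compound 4 is estimated at 70000 nM, within 20000 nM to 150000 nM.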

Compound 4, half-maximal inhibitory concentration: 94200 nM
Estimate against measurement, compound 4: 1.3-fold (0.13 log units) below, and the stated range covers the measured number.
By their numbers in this assay, from the lowest: compounds 3, 1 and 4 (each within the scatter of the next). At a limit, above all of these: compound 2.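

Putting 4-(methylsulfonyl)phenyl in place of 2-methyl-1,3-thiazol-4-yl on the carbonyl carbon gives an at least 1.0-fold lower number from compound 2 to compound 4 (0.02 log units; that floor lies within the scatter), so this change shows no clear gain. Compound 2 stands only at a limit of the assay: the limit of > 100000 nM in this assay, at which 1 of the 4 values shown sits. Compound 4 lies within the scatter of compound 1, so a quite different substituted phenyl on the carbonyl carbon still leaves the number weak.

On these data alone, what an open alkyl chain, or a ring carrying an amine or a carboxylic acid, would do at this place remains open. So does whether any group here can move the number beyond the scatter.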